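Fluorine added to the anilide ring of a pyridazinone amide

The source may report more compounds than this note shows. Statements on the series, on what has been measured and on what is new or still open speak of the compounds shown alone.

Measured so far:
compound 1, `CNC(=O)c1cc(Oc2ccc(NC(=O)c3nn(-c4ccc(Br)cc4F)c(=O)cc3C)cc2F)ccn1`: 9360 nM
compound 2, `Cc1cc(=O)n(-c2ccc(Br)cc2F)nc1C(=O)Nc1ccc(Oc2ncnc3sccc23)cc1`: 15200 nM

In a functional assay on MCF7 cells (Homo sapiens) for cytotoxicity, read by MTT assay, with a stated time of 72 h (a higher number here means a weaker inhibitor, a lower number a stronger inhibitor), compound 1 gives 9360 nM and compound 2 gives 15200 nM. The two numbers sit within the usual scatter of each other, so on the evidence of this pair compound 2 stands level with compound 1, and no ordering between them can be read. For the measured compounds named here, the two compounds differ in more than one place, so no single step connects them.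

Compound 3, `Cc1cc(=O)n(-c2ccc(Br)cc2F)nc1C(=O)Nc1ccc(Oc2ncnc3sccc23)c(F)c1`, is the next compound to be measured in this assay. It differs from compound 2 by fluoro in place of hydrogen on an aromatic carbon. Going by the values given here, the change is small in size, and no measured pair shows what it does. It is expected that the step of a 1.3-fold lower number from compound 2 to compound 3 (0.10 log units; within the scatter) stays within the scatter. Compound 3 is accordingly estimated at 12000 nM, with a range from 4500 nM to 32000 nM.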

Compound 3, half-maximal inhibitory concentration: 13300 nM
The estimate for compound 3 lay 1.1-fold (0.04 log units) below the measured number; low and high end bracket the measured number.
By their numbers in this assay, from the lowest: compounds 1, 3 and 2 (each within the scatter of the next).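

In this assay, fluoro in place of hydrogen on an aromatic carbon, ortho to a large group and meta to a large group, gives a 1.1-fold lower number from compound 2 to compound 3 (0.06 log units; within the scatter) and so produces no readable change at this position. With that fluoro present on both compounds, exchanging the whole group on the oxygen on an aromatic ring gives a 1.4-fold higher number from compound 1 to compound 3 (0.15 log units; within the scatter) and likewise cannot be read as a change. Nothing available bears on these results.

Going by these compounds, whether chlorine, a methoxy group or an amine on this same carbon would carry the number beyond the scatter remains open. Also open, on these data alone, is whether fluoro would give the same result on the other carbons of this ring, or with the group of compound 1 on the oxygen in a compound lacking it.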